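A Methyl Swap on the Carbonyl-Bound Phenyl Ring

This account rests on a few compounds, and the source may have more. Where it says the series, first, only, none or still open, it means among the compounds named here.

Compound 2 `COc1cc(-c2nnc3n2NC(c2ccco2)C(C(=O)c2ccccc2F)S3)cc(OC)c1OC` is one of three analogues that share a common core and differ only in the phenyl ring attached to the carbonyl carbon. In a functional assay on PC-3 cells (Homo sapiens) for cytotoxicity, read by MTT assay, with a stated time of 48 h (on this read-out lower numbers stand for stronger inhibition and higher numbers for weaker inhibition), compound 2 reaches only the assay limit of > 100000 nM, so its place on the scale is bounded rather than fixed (the limit of > 100000 nM in this assay, at which 1 of the 3 values shown sits). Compound 1 `COc1cc(-c2nnc3n2NC(c2ccco2)C(C(=O)c2ccccc2C)S3)cc(OC)c1OC` gives 88400 nM in this assay, and compound 3 `COc1cc(-c2nnc3n2NC(c2ccco2)C(C(=O)c2ccc(Br)cc2)S3)cc(OC)c1OC` gives 36400 nM. The untested compound 4 `COc1cc(-c2nnc3n2NC(c2ccco2)C(C(=O)c2ccc(C)cc2)S3)cc(OC)c1OC` differs from compound 2 by 4-methylphenyl in place of 2-fluorophenyl on a carbonyl carbon. Among the compounds with values here, two measured steps bear on this change. The step of an at least 1.1-fold higher number from compound 1 to compound 2 (0.05 log units; that floor lies within the scatter) shows that 2-fluorophenyl and 2-methylphenyl sit close together. The step of an at least 2.7-fold lower number from compound 2 to compound 3 (0.43 log units; beyond the scatter), like a 2.4-fold lower number from compound 1 to compound 3 (0.39 log units; beyond the scatter), shows that a 4-bromophenyl gives a lower number than either 2-substituted ring. Compound 4 carries a 4-methylphenyl, closer in kind to the 4-bromophenyl of compound 3 than to the 2-fluorophenyl of compound 2, so a modest decrease is expected: an at least 2.2-fold lower number from compound 2 to compound 4 (0.34 log units; beyond the scatter). Compound 4 is therefore estimated at 45000 nM, within 15000 nM to 120000 nM.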

Compound 4, half-maximal inhibitory concentration: 7500 nM
Compound 4: the middle estimate sits 6.0-fold (0.78 log units) above what was measured; the measured number lies below the stated range.
By their numbers in this assay, from the lowest: compound 4; then compound 3; then compound 1. At a limit, above all of these: compound 2.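

The earlier compounds shown here showed only a modest drop on going to a 4-bromophenyl, whereas in this assay the same methyl group on a 4-methylphenyl rather than a 2-methylphenyl gives a far larger change: a 12-fold lower number from compound 1 to compound 4 (1.07 log units; beyond the scatter). The identity of the group on the ring also counts, not only the ring pattern, since methyl in place of bromo gives a 4.9-fold lower number from compound 3 to compound 4 (0.69 log units; beyond the scatter), which leaves compound 4 with the lowest number of the four. Against the 2-fluorophenyl the change is an at least 13-fold lower number from compound 2 to compound 4 (1.12 log units; beyond the scatter), a floor rather than an exact size, as compound 2 remains a limit and not a number: the limit of > 100000 nM in this assay, at which 1 of the 4 values shown sits.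

The compounds shown leave open whether an ethyl or a methoxy group in place of that methyl would lower the number further. They also leave open whether an amine or a carboxylic acid would be tolerated on this ring.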